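The compounds below may be only part of what the source reports. "The series", "measured", "known", "first", "only" and "open" are said of these compounds alone.

Measured compounds:
Compound 1, `Cc1cccc(NC(=O)Nc2cccc(CNc3nccnc3Cl)c2)c1`: in a functional assay on T-24 cells (Homo sapiens) for antiproliferative activity, read by MTT assay, with a stated time of 48 h (a higher number here means a weaker inhibitor, a lower number a stronger inhibitor), compound 1 gives 9570 nM.
Compound 2, `O=C(Nc1cccc(CNc2nccnc2Cl)c1)Nc1cccc(C(F)(F)F)c1`: in this assay compound 2 gives 5080 nM.

For the measured compounds named here, compound 1 has the higher of the two numbers, and the only measured step, a 1.9-fold lower number from compound 1 to compound 2 (0.28 log units; within the scatter), does not part it from compound 2. The unmeasured compound 3 is `O=C(Nc1cccc(CNc2nccnc2Cl)c1)NC1CCCCC1`. It differs from compound 1 in one place: cyclohexyl in place of 3-methylphenyl on an amide-type nitrogen. Going by the values given here, no measured step touches this kind of change; the single step available swaps one group for another on an aromatic carbon, which is a different matter, and it stayed within the scatter. With nothing to show that this position moves the number, no step beyond the scatter is expected in this assay, though the range is kept wide. Compound 3 is estimated at 12000 nM, between 4000 nM and 35000 nM, which means an expected step of a 1.3-fold higher number from compound 1 to compound 3 (0.10 log units; within the scatter).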

Compound 3, half-maximal inhibitory concentration: > 40000 nM
Compound 3: no number, only a limit (the forecaster's own chance of this, stated with the estimate: 15%); at least 3.3-fold (0.52 log units) between middle value and limit.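

Compound 3 gives > 40000 nM in this assay, and this is a limit of the assay, not a number. Even so, putting cyclohexyl in place of 3-methylphenyl on the amide-type nitrogen produces an at least 4.1-fold higher number from compound 1 to compound 3 (0.62 log units; beyond the scatter), so this position can move the number, which the earlier step on an aromatic carbon, within the scatter, could not show. The full size of the step stays unknown because the reading for compound 3 ends at a limit: the limit of > 40000 nM in this assay, at which 1 of the 3 values shown sits.

This single pair cannot tell whether the aromatic ring itself matters or whether cyclohexyl is a poor fit in some other way. As far as these compounds go, it remains open what an unsubstituted phenyl, a pyridine ring or a longer chain such as hexyl would give on this nitrogen.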